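Changing the ester side group on a shared core

The compounds below may be only part of what the source reports. "The series", "measured", "known", "first", "only" and "open" are said of these compounds alone.

Compound 1 `CC(C)(C)C(=O)OC1CC2(N3CCCCC3)CC(c3ccccc3)C1C(c1ccccc1)C2` gives 12000 nM
Compound 2 `O=C(/C=C/c1ccccc1)OC1CC2(N3CCCCC3)CC(c3ccccc3)C1C(c1ccccc1)C2` gives 10500 nM

Going by the values given here, in an ADME assay on L6 cells (Rattus norvegicus) for cytotoxicity, with a stated time of 72 h (on this read-out higher numbers stand for weaker inhibition and lower numbers for stronger inhibition), compound 2 stands at 10500 nM, within the usual scatter of the only other measured compound. Compound 3 `O=C(CN1CCCC1)OC1CC2(N3CCCCC3)CC(c3ccccc3)C1C(c1ccccc1)C2` has not yet been measured. It carries (pyrrolidin-1-yl)methyl in place of 2-phenylethenyl on a carbonyl carbon. Among the compounds with values here, one measured step bears on this change, at the same place: a 1.1-fold lower number from compound 1 to compound 2 (0.06 log units; within the scatter). Within the data shown here, that swap of tert-butyl for 2-phenylethenyl stayed within the scatter, although no measured compound yet carries the entering group, so the evidence is indirect. On that single step, no change beyond the scatter is expected in this assay. The estimated change is a 1.3-fold higher number from compound 2 to compound 3 (0.12 log units; within the scatter). For compound 3 the estimated value is 14000 nM, with an expected range from 6000 nM to 35000 nM.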

Compound 3, half-maximal inhibitory concentration: 16400 nM
Estimate against measurement, compound 3: 1.2-fold (0.07 log units) below, within the range that was stated.
By their numbers in this assay, from the lowest: compounds 2, 1 and 3 (each within the scatter of the next).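

In this assay, (pyrrolidin-1-yl)methyl on the carbonyl carbon gives a 1.6-fold higher number from compound 2 to compound 3 (0.19 log units; within the scatter) against 2-phenylethenyl and a 1.4-fold higher number from compound 1 to compound 3 (0.14 log units; within the scatter) against tert-butyl. Until now only all-carbon side groups had been compared here, whereas the entering group brings a nitrogen and a hydrogen-bond acceptor, and neither step leaves the scatter. Across these three ester side groups, the numbers at this position therefore stay within the scatter of one another, and no other measurement bears on this result.

The compounds shown leave open whether a carboxylic acid, a primary amine or a longer chain on this carbonyl carbon would also stay within the scatter. They also leave open how these three compounds would compare on any read-out other than this assay.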